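From 2-phenylethenyl to 4-(methylsulfanyl)phenyl on the shared core

The source may hold more compounds than are shown below. What is called first, only, known or untested is meant among the compounds shown, and "the series" means these compounds.

In a functional assay on HeLa cells (Homo sapiens) for inhibition, read by MTT assay, with a stated time of 48 h (on this read-out higher numbers stand for weaker inhibition and lower numbers for stronger inhibition), compound 3 `C(=C/c1nc2ccccn2c1Sc1ccccc1)\c1ccccc1` gives 35500 nM. That value lies within the scatter of both relatives: compound 1 `CS(=O)(=O)c1ccc(-c2nc3ccccn3c2Sc2ccccc2)cc1` gives 70600 nM, and compound 2 `CCc1ccc(-c2nc3ccccn3c2Sc2ccccc2)cc1` gives 52100 nM. Compound 4 `CSc1ccc(-c2nc3ccccn3c2Sc2ccccc2)cc1` carries 4-(methylsulfanyl)phenyl in place of 2-phenylethenyl on an aromatic carbon. Among the measured compounds shown here, two measured steps bear on this change, a 1.4-fold lower number from compound 1 to compound 2 (0.13 log units; within the scatter) and a 1.5-fold lower number from compound 2 to compound 3 (0.17 log units; within the scatter), and both stayed within the scatter. Like compound 1 and compound 2, compound 4 has a substituted phenyl ring at this place, so no change beyond the scatter is expected. The expected step is a 1.5-fold higher number from compound 3 to compound 4 (0.19 log units; within the scatter). Compound 4 is estimated at 55000 nM, with an expected range of 28000 nM to 105000 nM.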

Compound 4, half-maximal inhibitory concentration: 30000 nM
For compound 4 the middle estimate is 1.8-fold (0.26 log units) above the measured one; the range from low to high includes it.
By their numbers in this assay, from the lowest: compounds 4, 3, 2 and 1 (each within the scatter of the next, the first and the last beyond it).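

In this assay the swap of 2-phenylethenyl for 4-(methylsulfanyl)phenyl gives a 1.2-fold lower number from compound 3 to compound 4 (0.07 log units; within the scatter) and methylsulfanyl in place of ethyl gives a 1.7-fold lower number from compound 2 to compound 4 (0.24 log units; within the scatter) so neither change separates these compounds. Methylsulfanyl in place of methylsulfonyl gives a 2.4-fold lower number from compound 1 to compound 4 (0.37 log units; beyond the scatter) and this modest step is the only one of the three beyond the scatter. Nothing available explains that difference. Still open, from the compounds shown here alone, is how an amine or a carboxylic acid on this phenyl ring would compare, and whether a longer chain on the sulfur would shift the number.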